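The source may report more compounds than this note shows. Statements on the series, on what has been measured and on what is new or still open speak of the compounds shown alone.

Measured compounds in a functional assay on MCF7 cells (Homo sapiens) for cytotoxicity, read by MTT assay, with a stated time of 72 h; on this read-out lower numbers stand for stronger inhibition of growth and higher numbers for weaker inhibition of growth:
- compound 1 `Cc1ccc(/C=C(/C#N)C(=O)c2ccc[nH]2)cc1`: 39000 nM
- compound 2 `N#C/C(=C/c1ccc(Cl)cc1)C(=O)c1ccc[nH]1`: 84000 nM
- compound 3 `N#C/C(=C/c1ccc([N+](=O)[O-])cc1)C(=O)c1ccc[nH]1`: 19000 nM

Compound 2 gives the highest number of the three in this assay; compound 1 is nearest, with a 2.2-fold higher number from compound 1 to compound 2 (0.33 log units; beyond the scatter) separating them, and compound 3 is furthest, with a 4.4-fold lower number from compound 2 to compound 3 (0.65 log units; beyond the scatter). The third step, a 2.1-fold lower number from compound 1 to compound 3 (0.31 log units; beyond the scatter), completes the set; all three steps are modest.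

Compound 4 `N#C/C(=C/c1ccc(Cl)c(Cl)c1)C(=O)c1ccc[nH]1` differs from compound 2 by chloro in place of hydrogen on an aromatic carbon. Within the data shown here, none of the measured steps adds a second group to the ring; each swaps the single group already present, so the bearing on this step is indirect. Those swaps gave modest movements, and chloro on the ring left compound 2 as the highest number. With one chloro already present, a second is expected to move the number by a modest amount at most, most likely a somewhat lower number than compound 2, but a step within the scatter is also plausible.

Compound 4 is therefore estimated at 60000 nM in this assay, within 25000 nM to 150000 nM. This estimate means an expected step of a 1.4-fold lower number from compound 2 to compound 4 (0.15 log units; within the scatter).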

Compound 4, concentration for 50% growth inhibition: 14000 nM
The estimate for compound 4 lay 4.3-fold (0.63 log units) above the measured number, and the stated range ends above it.
By their numbers in this assay, from the lowest: compounds 4 and 3 (each within the scatter of the next); then compound 1; then compound 2.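

In this assay the ring position ortho to a chloro group and meta to a large group, which carries hydrogen in every earlier compound, proves able to shift the number: chloro in place of hydrogen there gives a 6.0-fold lower number from compound 2 to compound 4 (0.78 log units; beyond the scatter) and so moves well beyond the scatter. Chloro as such does not go with a higher number in this series, since chloro in place of methyl went the other way, with a 2.2-fold higher number from compound 1 to compound 2 (0.33 log units; beyond the scatter) as the step. No measurement at hand accounts for either step.

Among these compounds, only one compound carries a group at this position, so it stays open whether the step depends on the chloro already present. Also open, from the compounds shown here alone, is whether a different group here, such as methoxy or an amine, would move the number in the same direction.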